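A few compounds are considered here, and "the series" means these few. Any claim that something is new, unique, unknown or untested is made for them only; others in the source may bear on it.

Measured so far in a functional assay on SK-OV-3 cells (Homo sapiens) for cytotoxicity, read by sulforhodamine B assay, with a stated time of 48 h; a lower number here means a stronger inhibitor of growth, a higher number a weaker inhibitor of growth:
compound 1, `ClCc1ccc(Cn2cnc3c(Cl)ncnc32)cc1`: 3380 nM
compound 2, `ClCc1ccccc1Cn1cnc2nc(Cl)nc(Cl)c21`: 5880 nM

Compound 1 holds the lowest of the two numbers, but compound 2 lies within the usual scatter of it, so no order can be read from the pair. Compound 3, `ClCc1ccc(Cn2cnc3c(Cl)nc(Cl)nc32)cc1`, is not yet measured. It differs from compound 1 in one place: chloro in place of hydrogen on an aromatic carbon. Going by the values given here, no measured pair shows this change, so its size rests on expectation alone. For compound 3 a value of 3000 nM is expected in this assay, with a range from 1200 nM to 8000 nM. For compound 3 the expected step is a 1.1-fold lower number from compound 1 to compound 3 (0.05 log units; within the scatter), judged to stay within the scatter in no clear direction.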

Compound 3, concentration for 50% growth inhibition: 13500 nM
For compound 3 the middle estimate is 4.5-fold (0.65 log units) below the measured one, outside the stated range (above it).
By their numbers in this assay, from the lowest: compounds 1 and 2 (each within the scatter of the next); then compound 3.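

In this assay, going by these compounds alone, chloro in place of hydrogen on the aromatic carbon between two ring nitrogen atoms gives the first readable step: a 4.0-fold higher number from compound 1 to compound 3 (0.60 log units; beyond the scatter). This position is therefore not indifferent to substitution, and with chloro the change runs towards weaker growth inhibition. No supporting measurement bears on the origin of this step. Still open, going by these compounds, is whether an amine or a methoxy group at this position would give a step of similar size or direction, since a single substituent defines no trend.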